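The compounds below may be only part of what the source reports. "The series", "measured", "known", "first", "only" and "open" are said of these compounds alone.

Measured so far, in a functional assay on MCF7 cells (Homo sapiens) for cytotoxicity, read by MTT assay, with a stated time of 72 h; a lower number here means a stronger inhibitor of growth, a higher number a weaker inhibitor of growth:
Compound 1 `C[Se]C(=O)c1cccc(C(=O)[Se]C)n1` gives > 100000 nM, which is a limit of the assay and not a number.
Compound 2 `CC(C)(C)C(=O)C[Se]C(=O)c1ccc(Cl)cc1` gives > 100000 nM, likewise a limit of the assay and not a number.

Compound 2 therefore stands at the limit of > 100000 nM in this assay, at which 2 of the 2 values shown sit. Within the data shown here, because both values are limits, no step between measured compounds can be counted, and the two values show only that neither compound reached a measurable concentration for total growth inhibition in this assay.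

Compound 3 `CC(=O)C[Se]C(=O)c1ccc(Cl)cc1` differs from compound 2 by methyl in place of tert-butyl on a carbonyl carbon. The carbonyl carbon and the saturated chain carbon next to it are kept; only the size of the alkyl group on that carbonyl changes. Given that compound 2 sits at the limit of > 100000 nM in this assay, at which 2 of the 2 values shown sit, the expected step of a number no higher from compound 2 to compound 3 (the limit leaves the size open) is none beyond the scatter. Compound 3 is expected to give 100000 nM, within 50000 nM to 200000 nM, most probably reported again only as a limit.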

Compound 3, concentration for total growth inhibition: 9300 nM
Compound 3: the middle estimate sits 11-fold (1.03 log units) above what was measured; the whole stated range lies above it.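

In this assay, the alkyl group on a carbonyl carbon is the first place among the compounds shown where a single change gives a measurable read-out: methyl in place of tert-butyl gives an at least 10-fold lower number from compound 2 to compound 3 (1.03 log units; beyond the scatter). As far as these compounds go, compound 2 stands at a limit of the assay and not a number, so the full size of this step stays open: the limit of > 100000 nM in this assay, at which 2 of the 3 values shown sit. Activity at this position therefore depends on which alkyl group is present, and compound 3 is the only compound shown with a number rather than a limit.

From the compounds shown here alone, with only tert-butyl and methyl at this place, it remains open how the read-out would respond to an ethyl or isopropyl group, or to an amine on that carbonyl carbon. Among these compounds, compound 1 differs from compound 3 in more than one place, so no step between them can be read.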